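The compounds below may be only part of what the source reports. "The series", "measured", "known", "first", "only" and "open" are said of these compounds alone.

Of the compounds shown here, three that share one core have been tested in a functional assay on T47D cells (Homo sapiens) for cytotoxicity, read by MTT assay, with a stated time of 2 days; on this read-out lower numbers stand for stronger inhibition and higher numbers for weaker inhibition. Compound 1 `Cc1ccc2c(=O)[nH]c(-c3cccc(F)c3)nc2c1` carries a fluoro on its pendant aromatic ring. In this assay compound 1 reaches only the limit of the assay, at > 50000 nM, so no number is known for it. Compound 2 `Cc1ccc2c(=O)[nH]c(-c3ccccc3OC(F)(F)F)nc2c1` likewise gives only a limit in this assay, at > 50000 nM. For the measured compounds named here, compound 3 `Cc1ccc2nc(-c3ccccc3N(C)C)[nH]c(=O)c2c1` is the one compound with a number: in this assay compound 3 gives 26700 nM. Compound 1 therefore stands at the limit of > 50000 nM in this assay, at which 2 of the 3 values shown sit, together with compound 2, and whether it lies within the scatter of compound 3 cannot be told from a limit.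

Compound 4 `Cc1ccc2c(=O)[nH]c(-c3cccc(C(F)(F)F)c3)nc2c1` differs from compound 1 in one place: trifluoromethyl in place of fluoro on an aromatic carbon. Going by the values given here, no pair of measured compounds records this change, so the step from compound 1 to compound 4 has no measured counterpart, and it is expected to be small, if any, in either direction. Because compound 1 sits at the limit of > 50000 nM in this assay, at which 2 of the 3 values shown sit, a weak reading is expected for compound 4 as well. Compound 4 is estimated at 40000 nM, with a range from 15000 nM to 100000 nM. That estimate means an expected step of an at least 1.2-fold lower number from compound 1 to compound 4 (0.09 log units; that floor lies within the scatter).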

Compound 4, half-maximal inhibitory concentration: > 50000 nM
Compound 4: a limit, no number; the forecaster's own chance of this, stated with the estimate: 60%; middle value at least 1.2-fold (0.09 log units) from the limit.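

In this assay, for the compounds shown here, compound 4 gives only a limit, > 50000 nM, and compound 1 also gives only a limit, so no step between compound 1 and compound 4 can be read. As far as these compounds go, whether trifluoromethyl in place of fluoro on the aromatic carbon changes the read-out at all, and in which direction, stays open.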